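A few compounds are considered here, and "the series" means these few. Any claim that something is new, unique, unknown or untested is made for them only; others in the source may bear on it.

Series notes. Compound 1 `CC(C)c1[nH]cnc1/C=c1\[nH]c(=O)/c(=C/c2cccc(Oc3ccc(F)cc3)c2)[nH]c1=O` gives 3.4 nM in a functional assay on BXPC-3 cells (Homo sapiens) for cytotoxicity, read by MTT assay, with a stated time of 72 h; on this read-out higher numbers stand for weaker inhibition and lower numbers for stronger inhibition. Compound 2 `CC(C)c1[nH]cnc1/C=c1\[nH]c(=O)/c(=C/c2cccc(C(=O)c3ccc(F)cc3)c2)[nH]c1=O` differs from it by (4-fluorophenyl)carbonyl in place of 4-fluorophenoxy on an aromatic carbon and gives 0.6 nM in this assay; the step is a 5.7-fold lower number from compound 1 to compound 2 (0.75 log units; beyond the scatter). Compound 3 `COCc1ccc(/C=c2\[nH]c(=O)/c(=C/c3cccc(Oc4ccc(F)cc4)c3)[nH]c2=O)o1` carries a different core, the difference from compound 1 being (5-(methoxymethyl)furan-2-yl in place of 5-isopropyl-1H-imidazol-4-yl on a double-bonded chain carbon bound to an aromatic carbon); in this assay compound 3 gives 6.6 nM, and the step is a 1.9-fold higher number from compound 1 to compound 3 (0.29 log units; within the scatter).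

Compound 4 `COCc1ccc(/C=c2\[nH]c(=O)/c(=C/c3cccc(C(=O)c4ccc(F)cc4)c3)[nH]c2=O)o1` is not yet measured. It differs from compound 3 by (4-fluorophenyl)carbonyl in place of 4-fluorophenoxy on an aromatic carbon, the same change as that from compound 1 to compound 2, made at the same place on the same kind of ring. For the measured compounds named here, the expectation for compound 4 rests on the one earlier instance, compound 1 to compound 2, because a 5.7-fold lower number from compound 1 to compound 2 (0.75 log units; beyond the scatter) was a step beyond the scatter. From the compounds shown here alone, whether the other core carries the change to the same extent is unknown, so a somewhat smaller step is estimated for compound 3 to compound 4, a 4.4-fold lower number from compound 3 to compound 4 (0.64 log units; beyond the scatter). In this assay compound 4 is therefore expected to give about 1.5 nM, estimated between 0.5 nM and 4.5 nM.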

Compound 4, half-maximal inhibitory concentration: 2 nM
Compound 4: middle estimate off by 1.3-fold (0.12 log units), on the low side; the measured number falls inside the stated range.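

In this assay, (4-fluorophenyl)carbonyl in place of 4-fluorophenoxy again lowers the number on the second core, giving a 3.3-fold lower number from compound 3 to compound 4 (0.52 log units; beyond the scatter), and the two instances of this change agree: the same change on two cores in this assay, a 5.7-fold lower number (0.75 log units; beyond the scatter) from compound 1 to compound 2 and a 3.3-fold lower number (0.52 log units; beyond the scatter) from compound 3 to compound 4, 1.7-fold (0.23 log units) apart, within the scatter of two such steps Read the other way, 5-(methoxymethyl)furan-2-yl in place of 5-isopropyl-1H-imidazol-4-yl gives a 3.3-fold higher number from compound 2 to compound 4 (0.52 log units; beyond the scatter), and this step also agrees with its earlier instance, although only the newer step lies beyond the scatter: the same change on two cores in this assay, a 1.9-fold higher number (0.29 log units; within the scatter) from compound 1 to compound 3 and a 3.3-fold higher number (0.52 log units; beyond the scatter) from compound 2 to compound 4, 1.7-fold (0.23 log units) apart, within the scatter of two such steps Among these four compounds the change on the aromatic carbon therefore carries from one core to the other in direction and, within the scatter, in size, but two instances on two cores do not show that it would carry to any further core, nor do they explain the effect.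

Open, from the compounds shown here alone, is how an amine or a longer chain in place of the carbonyl would behave in this assay. Also open, going by these compounds, is whether the step would hold on a core bearing a carboxylic acid in place of the methoxymethyl group.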